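A few compounds are considered here, and "the series" means these few. Any claim that something is new, unique, unknown or untested is made for them only; others in the source may bear on it.

Measured so far in a functional assay on KB cells (nasopharynx, Homo sapiens) for antiproliferative activity; a lower number here means a stronger inhibitor, a higher number a weaker inhibitor:
Compound 1 `COc1ccc(S(=O)(=O)Nc2cccc3c(C#N)c[nH]c23)cc1`: 1.4 ug/mL
Compound 2 `N#Cc1c[nH]c2c(NS(=O)(=O)c3ccc(C(=O)O)cc3)cccc12`: > 100 ug/mL (a limit)

Compound 2 stands at the limit of > 100 ug/mL in this assay, at which 1 of the 2 values shown sits, and is known only by that limit. Compound 3 `CS(=O)(=O)Nc1ccc(S(=O)(=O)Nc2cccc3c(C#N)c[nH]c23)cc1` carries methanesulfonamido in place of carboxy on an aromatic carbon. Within the data shown here, one measured step bears on this change, an at least 71-fold higher number from compound 1 to compound 2 (1.85 log units; beyond the scatter), with carboxy in place of methoxy on an aromatic carbon. Among the measured compounds shown here, with carboxy gone from compound 3, a large step to a lower number is expected in this assay, towards compound 1 at 1.4 ug/mL, though no measured step covers methanesulfonamido. The expected step is an at least 16-fold lower number from compound 2 to compound 3 (1.22 log units; beyond the scatter). For compound 3 the estimate is 6 ug/mL, with an expected range from 0.8 ug/mL to 50 ug/mL.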

Compound 3, half-maximal inhibitory concentration: 15 ug/mL
Estimate against measurement, compound 3: 2.5-fold (0.40 log units) below; low and high end bracket the measured number.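

In this assay, replacing carboxy with methanesulfonamido gives an at least 6.6-fold lower number from compound 2 to compound 3 (0.82 log units; beyond the scatter) at this aromatic carbon, para to a large group, so a group other than methoxy can retain measurable activity here. Compound 2 is known only by a limit: the limit of > 100 ug/mL in this assay, at which 1 of the 3 values shown sits. Changing methoxy to methanesulfonamido still gives an 11-fold higher number from compound 1 to compound 3 (1.03 log units; beyond the scatter) in this assay, so the two groups are not interchangeable at this position. The compounds shown leave open how an amine, a hydroxy group or a longer alkoxy chain would behave on this carbon.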